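Biaryl sulfonamides: cytotoxicity in HCT-116 cells

This account rests on a few compounds, and the source may have more. Where it says the series, first, only, none or still open, it means among the compounds named here.

Compound 1 `CC1CCN(C2CCN(S(=O)(=O)c3cnc(Cl)s3)CC2)CC1` is the smaller member of the set. In an ADME assay on HCT-116 cells (Homo sapiens) for cytotoxicity, read by CellTiter-Glo, with a stated time of 72 h (a higher number here means a weaker inhibitor, a lower number a stronger inhibitor), compound 1 gives > 10000 nM, which is a limit of the assay and not a number. Compound 2 `CC1CCN(C2CCN(S(=O)(=O)c3cccc(-c4ccccc4F)c3)CC2)CC1` carries a 2-fluorophenyl on the shared core. In this assay compound 2 gives > 5000 nM, again a limit rather than a number. Among the compounds with values here, both measured values thus sit at limits, as the limit of > 10000 nM in this assay, at which 1 of the 2 values shown sits, and the limit of > 5000 nM in this assay, at which 1 of the 2 values shown sits, show, so no step between measured compounds can be sized and compound 2 stands only as a limit. Compound 3 `Cc1ccc(-c2cccc(S(=O)(=O)N3CCC(N4CCC(C)CC4)CC3)c2)cc1` differs from compound 2 in one place: 4-methylphenyl in place of 2-fluorophenyl on an aromatic carbon. With both known values at limits, no direction can be read for the step from compound 2 to compound 3 in this assay, and the expectation is a shift no larger than the usual scatter, most likely ending again at a limit. Compound 3 is expected to give 8000 nM, with a range from 3000 nM to 20000 nM, and the expected step that the limit leaves unreadable from compound 2 to compound 3 stays within the scatter.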

Compound 3, half-maximal inhibitory concentration: > 5000 nM
Compound 3 ended at the assay's limit (the forecaster's own chance of this, stated with the estimate: 70%); the middle value lies beyond the limit too.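

Within the data shown here, compound 2 and compound 3 both stand at limits in this assay, not at numbers, so no step between them can be read. The compounds shown leave open whether 4-methylphenyl in place of 2-fluorophenyl changes the read-out at all, and where any measurable half-maximal inhibitory concentration would lie.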